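Thiazole methylation on the cyclopropyl amide series

This account rests on a few compounds, and the source may have more. Where it says the series, first, only, none or still open, it means among the compounds named here.

Measured compounds:
- compound 1, `CC[C@H](C)[C@H](N)CN(C(=O)[C@@H]1C[C@H]1c1ccc(F)cc1)c1ccc(-c2ccccc2)cc1`: 600 nM
- compound 2, `CC[C@H](C)[C@H](N)CN(C(=O)[C@@H]1C[C@H]1c1ncc(C)s1)c1ccc(-c2ccccc2)cc1`: 1300 nM

In a functional assay for agonist activity at G protein-coupled receptor 88 (Homo sapiens), read by HTRF and cAMP accumulation (on this read-out lower numbers stand for an effect already at smaller amounts and higher numbers for an effect only at larger amounts of compound), compound 2 gives 1300 nM, the higher of the two numbers recorded; its nearest neighbour is compound 1, whose number is lower. Among the compounds with values here, the only step recorded so far is a 2.2-fold higher number from compound 1 to compound 2 (0.34 log units; beyond the scatter), a change of the group on the saturated ring carbon.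

Compound 3, `CC[C@H](C)[C@H](N)CN(C(=O)[C@@H]1C[C@H]1c1nc(C)c(C)s1)c1ccc(-c2ccccc2)cc1`, is not yet measured. It differs from compound 2 by methyl in place of hydrogen on an aromatic carbon: a single methyl added to the aromatic ring already present in compound 2, with the rest of the molecule unchanged.

Within the data shown here, no recorded step concerns a methyl added to this ring. Among the measured compounds shown here, the one step available shows that swapping the whole ring shifts this assay modestly; a single added methyl on the same ring is a smaller change than that, and no direction can be read from the data for it. The expectation for compound 3 is therefore no step beyond the scatter, no change at the digits printed from compound 2 to compound 3 (within the scatter). Compound 3 is estimated at 1300 nM, with a range from 500 nM to 3500 nM.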

Compound 3, half-maximal effective concentration: 3600 nM
Beside the measured number, compound 3's estimate is 2.8-fold (0.44 log units) below it, outside the stated range (above it).
By their numbers in this assay, from the lowest: compound 1; then compound 2; then compound 3.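

In this assay, this position on the thiazole, next to the ring nitrogen and next to the ring atom that bears a methyl group, does not tolerate the change silently: the added methyl gives a 2.8-fold higher number from compound 2 to compound 3 (0.44 log units; beyond the scatter) as a step of its own. A change of one heavy atom here is thus printed as modest, the same grade as the exchange of the whole ring, which gave a 2.2-fold higher number from compound 1 to compound 2 (0.34 log units; beyond the scatter) in the same direction, and the two changes together, 4,5-dimethyl-1,3-thiazol-2-yl in place of 4-fluorophenyl, give a 6.0-fold higher number from compound 1 to compound 3 (0.78 log units; beyond the scatter) and leave the 4-fluorophenyl compound with the lowest number of the three. No measurement is available that bears on the origin of this shift.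

Open, as far as these compounds go, is whether the rise in the number belongs to methyl alone or to any group at this carbon, as a chlorine atom, a hydroxymethyl group or an aminomethyl group here would show. Also open, from the compounds shown here alone, is how much of the effect depends on the methyl already present on the neighbouring ring atom, which the thiazole carrying only the new methyl, or an ethyl group in its place, would help to separate.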